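A few compounds are considered here, and "the series" means these few. Any claim that something is new, unique, unknown or untested is made for them only; others in the source may bear on it.

In a functional assay on KBVIN cells (Homo sapiens) for antiproliferative activity, read by sulforhodamine B assay, with a stated time of 3 days (on this read-out lower numbers stand for an effect already at smaller amounts and higher numbers for an effect only at larger amounts of compound), three compounds sharing one core have been measured. Compound 1 (`CCC1=C(O)c2c(oc(-c3ccc(CC)cc3)cc2=O)C(CC)(CC)C1=O`) gives 0.07 uM and stands apart from the other two. Compound 2 (`CCC1=C(O)c2c(oc(-c3ccc(C(C)C)cc3)cc2=O)C(CC)(CC)C1=O`) gives 1.08 uM as its number. Compound 3 (`CCC1=C(O)c2c(oc(-c3ccc(C)c(C)c3)cc2=O)C(CC)(CC)C1=O`) gives 0.71 uM as its number, level with compound 2 within the scatter and clearly higher than compound 1.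

The next compound, compound 4 (`CCC1=C(O)c2c(oc(-c3ccc(OC)cc3C)cc2=O)C(CC)(CC)C1=O`), carries 4-methoxy-2-methylphenyl in place of 3,4-dimethylphenyl on an aromatic carbon next to the ring oxygen (4-methoxy-2-methylphenyl in place of 3,4-dimethylphenyl on an aromatic carbon).

All three measured steps concern this same aryl group. Replacing 4-ethylphenyl with 3,4-dimethylphenyl gave a 10-fold higher number from compound 1 to compound 3 (1.01 log units; beyond the scatter) and putting methyl in place of hydrogen on the ethyl chain gave a 15-fold higher number from compound 1 to compound 2 (1.19 log units; beyond the scatter) so small edits here can count for a lot. Going by the values given here, none of the measured compounds carries a methoxy group, which leaves this change without a direct precedent. Compound 4 lacks the 4-ethylphenyl group of compound 1, and the remaining pair differ little, as a 1.5-fold lower number from compound 2 to compound 3 (0.18 log units; within the scatter) shows. No step beyond the scatter is therefore expected in this assay in either direction, although the uncertainty is wide. The expected change is a 1.0-fold lower number from compound 3 to compound 4 (0.01 log units; within the scatter) on this evidence. For compound 4 the estimated value is 0.7 uM with an expected range from 0.15 uM to 2.5 uM in this measurement.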

Compound 4, concentration for half-maximal effect: 2.62 uM
The estimate for compound 4 lay 3.7-fold (0.57 log units) below the measured number, outside the stated range (above it).
By their numbers in this assay, from the lowest: compound 1; then compounds 3 and 2 (each within the scatter of the next); then compound 4.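

In this assay, 4-methoxy-2-methylphenyl in place of 3,4-dimethylphenyl gives a 3.7-fold higher number from compound 3 to compound 4 (0.57 log units; beyond the scatter), and in place of 4-isopropylphenyl it gives a 2.4-fold higher number from compound 2 to compound 4 (0.38 log units; beyond the scatter), so this group stands clearly apart from two aryl groups whose numbers lie level within the scatter. Measured against the 4-ethylphenyl group, the same kind of exchange gives a 37-fold higher number from compound 1 to compound 4 (1.57 log units; beyond the scatter), the largest step in this set, and the four compounds now span a wide range through changes to this one aryl group alone. The exchange brings in a methoxy group and also changes where the methyl groups stand on the ring, so the step cannot be divided between these two changes, and no measurement here accounts for the rise.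

As far as these compounds go, it remains open whether an aryl group carrying the methoxy group without the methyl group would give a number nearer that of compound 3 or that of compound 4. Also open, from the compounds shown here alone, is how an amine or a carboxylic acid in place of the methoxy group would read, and whether a longer chain in place of the ethyl chain of compound 1 would keep its low number.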